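Changing the alkyne tail: butyl to cyclohexyl

A few compounds are considered here, and "the series" means these few. Any claim that something is new, unique, unknown or untested is made for them only; others in the source may bear on it.

Compound 1 `CC(=O)Nc1nc(-c2cccc(NS(=O)(=O)c3ccc(Br)cc3)c2)cs1`: "not active" (no number reported)
Compound 2 `CC(=O)Nc1nc(-c2cccc(NS(=O)(=O)c3cccc(Br)c3)c2)cs1`: "not active" (no number reported)
Compound 3 `CCCCC#Cc1ccc(S(=O)(=O)Nc2cccc(-c3csc(NC(C)=O)n3)c2)cc1`: 73.2%

In a functional assay on A-375 cells (Homo sapiens) for antiproliferative activity, read by trypan blue exclusion, with a stated time of 48 h, tested at 1 uM (on this read-out lower numbers stand for a stronger effect and higher numbers for a weaker effect at the one concentration tested), compound 1 is reported as "not active" (no number reported), and compound 2 likewise as "not active" (no number reported). Compound 3 gives 73.2% in this assay and so stands as the only one of the three for which a number is reported at all. Compound 4 `CC(=O)Nc1nc(-c2cccc(NS(=O)(=O)c3ccc(C#CC4CCCCC4)cc3)c2)cs1` has not been measured. It differs from compound 3 in a single place: cyclohexyl in place of butyl on a triple-bonded carbon. Among the measured compounds shown here, no step between measured compounds is available, so the effect of this change cannot be read from them; a small step, or none beyond the scatter, is expected, leaning if anything toward a stronger effect. Compound 4 is expected to give 68% in this assay, within 45% to 92%. The expected step is a number 5.2 percentage points lower from compound 3 to compound 4 (within the scatter).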

Compound 4, a percentage reported as activity, at one concentration (the size of the read-out at that concentration, not a potency): 52.3%
Beside the measured number, compound 4's estimate is 15.7 percentage points above it; low and high end bracket the measured number.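

In this assay cyclohexyl in place of butyl on a triple-bonded carbon gives a number 20.9 percentage points lower from compound 3 to compound 4 (beyond the scatter) and so a stronger effect at the one concentration tested. Among the compounds shown here, this is the first readable step, and it shows that the group carried on the triple-bonded carbon can change the read-out beyond the scatter. Nothing given here accounts for this step.

As far as these compounds go, whether a longer chain, a phenyl ring or an amine on the same carbon would strengthen the effect further remains open. So does whether the ring itself matters or simply the larger carbon count.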